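The source may hold more compounds than are shown below. What is called first, only, known or untested is meant among the compounds shown, and "the series" means these compounds.

Measured so far:
Compound 1 `Cn1c(=O)c(S(=O)(=O)c2ccc(F)cc2)cc2cnc(Nc3ccc4[nH]ccc4c3)nc21` gives 200 nM in a functional assay on K562 cells (Homo sapiens) for inhibition, read by trypan blue exclusion, with a stated time of 72 h; a lower number here means a stronger inhibitor, a higher number a weaker inhibitor.
Compound 2 `Cn1c(=O)c(S(=O)(=O)c2ccc(F)cc2[N+](=O)[O-])cc2cnc(Nc3ccc4[nH]ccc4c3)nc21` gives 900 nM in this assay.

Compound 1 holds the lowest of the two numbers; the nearest is compound 2, with a 4.5-fold higher number from compound 1 to compound 2 (0.65 log units; beyond the scatter). Compound 3 `Cn1c(=O)c(S(=O)(=O)c2ccc(F)cc2)cc2cnc(Nc3cnc4[nH]ccc4c3)nc21` differs from compound 1 by a group of 9 heavy atoms (7 carbon, 2 nitrogen; one five-membered aromatic ring with 1 hetero atom, one six-membered aromatic ring with 1 hetero atom) in place of a group of 9 heavy atoms (8 carbon, 1 nitrogen; one five-membered aromatic ring with 1 hetero atom, one six-membered aromatic ring of carbon only), on a nitrogen on an aromatic ring. Among the compounds with values here, the one measured step concerns a nitro group and does not bear on this exchange of ring systems, so no measured pair informs the change. No step beyond the scatter is therefore expected. Compound 3 is estimated at 250 nM, range 80 nM to 800 nM. For compound 3 this amounts to an expected 1.3-fold higher number from compound 1 to compound 3 (0.10 log units; within the scatter).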

Compound 3, half-maximal inhibitory concentration: 750 nM
Beside the measured number, compound 3's estimate is 3.0-fold (0.48 log units) below it, within the range that was stated.
By their numbers in this assay, from the lowest: compound 1; then compounds 3 and 2 (each within the scatter of the next).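

Notes on the group on the nitrogen on an aromatic ring: in this assay, 1H-indol-5-yl gives way to a group whose six-membered aromatic ring holds 1 hetero atom, which yields a 3.8-fold higher number from compound 1 to compound 3 (0.57 log units; beyond the scatter) and is the first reading at this place. The series therefore responds to a change within this ring system, not only to the nitro change on the aromatic sulfonyl group. No measurement at hand accounts for the step.

Still open, going by these compounds, is how an amine or a carboxylic acid on this ring system would read, and whether the nitro step would carry over to compound 3.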